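The source may report more compounds than this note shows. Statements on the series, on what has been measured and on what is new or still open speak of the compounds shown alone.

Working notes on the series.

Cytotoxicity is the only read-out here. Compound 1 `Fc1cccc(F)c1Cn1c(-c2c(F)cccc2F)nc2ccncc21`, measured in an ADME assay on MDBK cells (Bos taurus) for cytotoxicity (a lower number here means that less compound is tolerated, a higher number that more compound is tolerated), gives 99000 nM, a numerical value rather than a limit. Compound 2 `Fc1cccc(F)c1-c1nc2ccn(Cc3ccccc3)cc-2n1` does not reach a number in this assay and is reported only at the assay limit, > 100000 nM. Compound 3 `COc1ccc(Cn2ccc3nc(-c4ccccc4)nc-3c2)cc1` is likewise reported only at the assay limit, > 100000 nM.

Compound 3 therefore stands without a number of its own: its value is a limit, and one further value in the set is a limit as well, namely (the limit of > 100000 nM in this assay, at which 2 of the 3 values shown sit). Among the compounds with values here, the one numerical value, that of compound 1, sits close to that limit. Within the data shown here, no pair of measured compounds differs in a single place, so no measured step is available to carry over.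

Compound 4 `N#Cc1ccccc1Cn1ccc2nc(-c3ccccc3)nc-2c1` is the next compound, not yet measured. It differs from compound 3 by 2-cyanophenyl in place of 4-methoxyphenyl on a saturated chain carbon bound to an aromatic nitrogen. Among the measured compounds shown here, with no measured step to lean on and two of three values at the assay limit, the step from compound 3 to compound 4 in this assay is expected to be none beyond the usual scatter, a number no higher from compound 3 to compound 4 (the limit leaves the size open). Compound 4 is accordingly estimated at 100000 nM, with a range from 50000 nM to 200000 nM, and a real chance that only a limit is returned again.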

Compound 4, half-maximal cytotoxic concentration: > 100000 nM
Compound 4 gave a limit, no number; the forecaster's own chance of this, stated with the estimate: 60%; the middle value sits exactly at the limit.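

Within the data shown here, compound 3 and compound 4 both stand only at a limit, so no step between them can be read in this assay: the limit of > 100000 nM in this assay, at which 3 of the 4 values shown sit.

The compounds shown leave open whether 2-cyanophenyl in place of 4-methoxyphenyl on a saturated chain carbon bound to an aromatic nitrogen shifts the tolerated concentration at all.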